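This account rests on a few compounds, and the source may have more. Where it says the series, first, only, none or still open, it means among the compounds named here.

The measured compounds:

compound 1 `NC(=S)N/N=C/c1ccc2ccccc2n1` — 100000 nM
compound 2 `Cc1ccc(NC(=S)N/N=C/c2ccc3ccccc3n2)cc1` — 85500 nM

Both numbers come from a functional assay on HT-29 cells (Homo sapiens) for antiproliferative activity, read by sulforhodamine B assay, with a stated time of 72 h; a higher number here means a weaker inhibitor, a lower number a stronger inhibitor. Compound 2 gives the lowest of the two numbers, and its nearest neighbour is compound 1; the two lie within the scatter of each other, so neither is called the stronger inhibitor. For the measured compounds named here, the only measured step, a 1.2-fold lower number from compound 1 to compound 2 (0.07 log units; within the scatter), puts 4-methylphenyl in place of hydrogen on an amide-type nitrogen and stays within the scatter.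

Compound 3 `S=C(N/N=C/c1ccc2ccccc2n1)Nc1ccccc1Br` differs from compound 2 in one place: 2-bromophenyl in place of 4-methylphenyl on an amide-type nitrogen. Going by the values given here, no measured step exchanges one aryl group for another on this nitrogen. Among the compounds with values here, the one step that touches this nitrogen, a 1.2-fold lower number from compound 1 to compound 2 (0.07 log units; within the scatter), was within the scatter, so no movement beyond the scatter is expected in this assay. Compound 3 is therefore expected to give 75000 nM, in a range from 25000 nM to 200000 nM. That estimate means an expected step of a 1.1-fold lower number from compound 2 to compound 3 (0.06 log units; within the scatter).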

Compound 3, half-maximal inhibitory concentration: > 100000 nM
Compound 3 ended at the assay's limit (the forecaster's own chance of this, stated with the estimate: 30%); at least 1.3-fold (0.12 log units) between middle value and limit.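

Compound 3 reads as a limit of the assay, not a number, in this assay: the limit of > 100000 nM in this assay, at which 1 of the 3 values shown sits.

The exchange of 4-methylphenyl for 2-bromophenyl on the amide-type nitrogen is the only step shown that replaces one aryl group with another, and it gives an at least 1.1-fold higher number from compound 2 to compound 3 (0.06 log units; that floor lies within the scatter). As far as these compounds go, with 2-bromophenyl on this nitrogen, no lower number appears, but how far the true value of compound 3 lies from the other two stays unknown, and putting 2-bromophenyl in place of hydrogen on this nitrogen gives a number no lower from compound 1 to compound 3 (the limit leaves the size open).

The compounds shown leave open whether any other group on this nitrogen brings the number down. A phenyl ring carrying an amine or a carboxylic acid, or a simple alkyl chain in place of the aryl group, is not among them.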